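The compounds below may be only part of what the source reports. "The series", "measured", "known", "first", "only" and "open" are said of these compounds alone.

Compound 1 `C/N=C(\S)NCCCCCn1nc(-c2ccccc2)ccc1=O` is the starting point. Among the measured compounds shown here, in a functional assay on the whole organism with Rattus norvegicus as the target, at a dose of 100 mg/kg (on this read-out higher numbers stand for more inhibition at the one dose given (going by the name of the read-out) and lower numbers for less inhibition), compound 1 gives 68.9%, the highest of the three numbers measured so far. Compound 2 `CCC/N=C(/NC#N)NCCCCCn1nc(-c2ccccc2)ccc1=O` gives 27.5% and compound 3 `CC/N=C(/NC#N)NCCCCCCn1nc(-c2ccccc2)ccc1=O` gives 29.1%; these two sit within the scatter of each other (a number 1.6 percentage points higher from compound 2 to compound 3 (within the scatter)).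

Compound 4 `N/C(S)=N/CCCCn1nc(-c2ccccc2)ccc1=O` differs from compound 1 by a group of 4 heavy atoms (1 carbon, 2 nitrogen, 1 sulfur; no ring) in place of a group of 6 heavy atoms (3 carbon, 2 nitrogen, 1 sulfur; no ring), on a saturated chain carbon, four bonds along the chain from an aromatic nitrogen. For the measured compounds named here, two measured steps bear on this change, both swapping the sulfur-bearing group for a larger nitrogen-rich one: a number 41.4 percentage points lower from compound 1 to compound 2 (beyond the scatter) and a number 39.8 percentage points lower from compound 1 to compound 3 (beyond the scatter). Compound 4 keeps a sulfur-bearing group, so the expected step is small, a number 10.9 percentage points lower from compound 1 to compound 4 (beyond the scatter), with wide uncertainty. Compound 4 is therefore estimated at 58%, ranging from 30% to 82%.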

Compound 4, a percentage reported as inhibition, in the whole organism at one dose (the size of the read-out at that dose, not a potency): 72%
For compound 4 the middle estimate is 14 percentage points below the measured one, and the stated range covers the measured number.
By their numbers in this assay, from the lowest: compounds 2 and 3 (each within the scatter of the next); then compounds 1 and 4 (each within the scatter of the next).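

Swapping the group of 6 heavy atoms for the smaller group of 4 heavy atoms, on a saturated chain carbon, four bonds along the chain from an aromatic nitrogen, leaves this assay within the scatter (a number 3.1 percentage points higher from compound 1 to compound 4 (within the scatter)). The earlier steps shown here showed only large drops on moving to bigger nitrogen-rich groups, while this one shows that a smaller sulfur-bearing group keeps the inhibition. Nothing available explains this result.

As far as these compounds go, it remains open whether an amine in place of the sulfur-bearing group would keep this inhibition. A longer chain carrying the same sulfur-bearing group is equally untested here.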